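Adding a 4-chlorobenzyl to the ring nitrogen of compound 1

The source may hold more compounds than are shown below. What is called first, only, known or untested is meant among the compounds shown, and "the series" means these compounds.

Measured so far:
compound 1 `O=C1Nc2ccc(Br)cc2/C1=N/NC(=S)Nc1ccc(Cl)cc1`: 61000 nM
compound 2 `Cc1ccc(NC(=S)N/N=C2\C(=O)Nc3ccc(Br)cc32)cc1`: 6800 nM
compound 3 `O=C1Nc2ccc(F)cc2/C1=N/NC(=S)Nc1ccc(Cl)cc1`: 25000 nM

In a functional assay on CCRF-CEM cells (Homo sapiens), with a stated time of 72 h (on this read-out lower numbers stand for stronger inhibition and higher numbers for weaker inhibition), compound 1 gives the highest number of the three, so it is the weakest inhibitor among them. Its nearest neighbour is compound 3, reached by a 2.4-fold lower number from compound 1 to compound 3 (0.39 log units; beyond the scatter); the furthest is compound 2, reached by a 9.0-fold lower number from compound 1 to compound 2 (0.95 log units; beyond the scatter). Both of these steps swap one substituent on an aromatic ring for another.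

Compound 4 `O=C1/C(=N\NC(=S)Nc2ccc(Cl)cc2)c2cc(Br)ccc2N1Cc1ccc(Cl)cc1` departs from compound 1 in a different place: 4-chlorobenzyl in place of hydrogen on an amide-type nitrogen in a ring. Among the compounds with values here, no measured step touches this nitrogen, so neither a 9.0-fold lower number from compound 1 to compound 2 (0.95 log units; beyond the scatter) nor a 2.4-fold lower number from compound 1 to compound 3 (0.39 log units; beyond the scatter) gives a direct template; they only show that single changes around the shared core have moved the number by modest amounts, always downward from compound 1. On that thin basis a modest downward step is expected, with wide uncertainty. For compound 4 in this assay the expected step is a 2.0-fold lower number from compound 1 to compound 4 (0.31 log units; beyond the scatter). Compound 4 is therefore estimated at 30000 nM, within 8000 nM to 120000 nM.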

Compound 4, half-maximal inhibitory concentration: 392000 nM
Beside the measured number, compound 4's estimate is 13-fold (1.12 log units) below it; measured number above the stated range.
By their numbers in this assay, from the lowest: compound 2; then compound 3; then compound 1; then compound 4.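

With a 6.4-fold higher number from compound 1 to compound 4 (0.81 log units; beyond the scatter) in this assay this is the first step shown that raises the number, so a change on the amide-type nitrogen in a ring weakens inhibition, whereas the two swaps on the aromatic rings strengthened it. The hydrogen on this nitrogen is therefore a place where the 4-chlorobenzyl group, with its six-membered aromatic ring, costs activity rather than gains it, at least on the core of compound 1. Nothing measured here says why this replacement has that effect.

From the compounds shown here alone, it remains open whether any group on this nitrogen does the same or only 4-chlorobenzyl does, which a small ethyl or a short chain ending in an amine could help to settle. Going by these compounds, it is also open whether the same change would weaken inhibition on compound 2 or compound 3.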